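The compounds below may be only part of what the source reports. "The series", "measured", "known", "first", "only" and "open" are said of these compounds alone.

Compound 1 `Cc1ccc(OCC(=O)NNC(=O)c2cc3ccccc3oc2=O)c(C(=O)c2cccc(Cl)c2)c1`: 67400 nM
Compound 2 `Cc1ccc(OCC(=O)NNC(=O)c2cc3ccccc3oc2=O)c(C(=O)c2ccccc2)c1`: 87000 nM
Compound 3 `Cc1ccc(OCC(=O)NNC(=O)c2cc3ccccc3oc2=O)c(C(=O)c2ccc(Cl)cc2)c1`: not yet measured

In a functional assay on DLA cells (Mus musculus) for cytotoxicity, read by LDH release, with a stated time of 48 h (on this read-out lower numbers stand for stronger inhibition and higher numbers for weaker inhibition), compound 2 stands at 87000 nM, within the scatter of compound 1. Compound 3 differs from compound 2 by chloro in place of hydrogen on an aromatic carbon, para to a large group. Among the compounds with values here, one measured step bears on this change, a 1.3-fold higher number from compound 1 to compound 2 (0.11 log units; within the scatter), which exchanges the same two substituents at a different aromatic carbon. On that basis no shift beyond the scatter is expected in this assay. The expected step is a 1.2-fold lower number from compound 2 to compound 3 (0.09 log units; within the scatter). For compound 3 the estimated value is 70000 nM, with an expected range of 32000 nM to 140000 nM.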

Compound 3, half-maximal inhibitory concentration: 60400 nM
For compound 3 the middle estimate is 1.2-fold (0.06 log units) above the measured one; measured number inside the range.
By their numbers in this assay, from the lowest: compounds 3, 1 and 2 (each within the scatter of the next).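

In this assay chloro para to a large group gives a 1.4-fold lower number from compound 2 to compound 3 (0.16 log units; within the scatter) and so, like the chloro of compound 1, leaves the number within the scatter. Exchanging 3-chlorophenyl for 4-chlorophenyl gives a 1.1-fold lower number from compound 1 to compound 3 (0.05 log units; within the scatter) and thus shows no separation between these two placements of chloro. No evidence is available on what lies behind these numbers. The compounds shown leave open whether an amine, a carboxylic acid or a methoxy group at this position on the ring would move the number beyond the scatter.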